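Replacing chloro with methoxy in compound 2

The compounds below may be only part of what the source reports. "The series", "measured", "known", "first", "only" and "open" are said of these compounds alone.

Measured in a functional assay on HCT-116 cells (Homo sapiens) for inhibition, read by MTT assay, with a stated time of 72 h; on this read-out lower numbers stand for stronger inhibition and higher numbers for weaker inhibition:
- compound 1 `Cc1cccc(CN2CCc3ncn(COCc4ccccc4)c3/C(=C/c3ccccc3)C2=O)c1` gives 3800 nM
- compound 2 `O=C1/C(=C\c2ccccc2)c2c(ncn2COCc2ccccc2)CCN1Cc1ccc(Cl)cc1` gives 10500 nM

Of the two measured compounds, compound 2 holds the higher number in this assay, which makes it the weaker inhibitor on this read-out. Going by the values given here, its only neighbour is compound 1 at 3800 nM.

The next compound, compound 3 `COc1ccc(CN2CCc3ncn(COCc4ccccc4)c3/C(=C/c3ccccc3)C2=O)cc1`, keeps the shared core and alters a single group: methoxy in place of chloro on an aromatic carbon. This puts methoxy in place of chloro on an aromatic carbon, para to a large group, so 4-chlorobenzyl becomes 4-methoxybenzyl.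

Among the compounds with values here, only one measured step bears on this change: a 2.8-fold higher number from compound 1 to compound 2 (0.44 log units; beyond the scatter). That modest step also brought in 4-chlorophenyl in place of 3-methylphenyl, so it alters both the group and its place on the ring. Within the data shown here, no measured compound carries methoxy, which leaves the direction uncertain. Among the measured compounds shown here, since compound 2 is the only chloro compound and compound 1 lies lower at 3800 nM, a modest move to a lower number is expected, no larger than the measured step. The estimated move is a 1.8-fold lower number from compound 2 to compound 3 (0.24 log units; within the scatter). Compound 3 is expected at 6000 nM, with an estimated range of 2200 nM to 16000 nM.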

Compound 3, half-maximal inhibitory concentration: 31100 nM
The estimate for compound 3 lay 5.2-fold (0.71 log units) below the measured number; the whole stated range lies below it.
By their numbers in this assay, from the lowest: compound 1; then compound 2; then compound 3.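

In this assay, the change from 4-chlorobenzyl to 4-methoxybenzyl gives a 3.0-fold higher number from compound 2 to compound 3 (0.47 log units; beyond the scatter), beyond the scatter. Going by these compounds alone, this is the first reading of a group exchanged at one fixed place, para to a large group, and it shows that the number at this place depends on the group alone; the earlier step had changed the group and its place on the ring together. Against the 3-methylphenyl of compound 1, the 4-methoxyphenyl group gives an 8.2-fold higher number from compound 1 to compound 3 (0.91 log units; beyond the scatter), which leaves compound 3 the weakest of the three inhibitors, though no measurement offered here explains this order.

Whether compound 1 owes its lower number to the methyl group itself or to that group's place on the ring stays open, as the compounds shown include no 4-methylphenyl partner to separate the two. With only chloro and methoxy compared at the same place, it is also unknown how a fluoro group, an amine or a carboxylic acid there would read, or whether any such group would bring the number below that of compound 1.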